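A third methoxy group on the cinnamate ester

The source may report more compounds than this note shows. Statements on the series, on what has been measured and on what is new or still open speak of the compounds shown alone.

Compound 1 `COc1ccc(/C=C/C(=O)OCc2nc(C)c(C)nc2C)cc1`: in a functional assay on PC-12 cells (Rattus norvegicus) (on this read-out higher numbers stand for an effect only at larger amounts of compound and lower numbers for an effect already at smaller amounts), compound 1 gives < 24000 nM, a limit of the assay and not a number.
Compound 2 `COc1ccc(/C=C/C(=O)OCc2nc(C)c(C)nc2C)cc1OC`: in this assay compound 2 gives < 24000 nM, again a limit of the assay and not a number.

Within the data shown here, compound 2 stands only at a limit in this assay, and the one other value shown for the pair is a limit as well (the limit of < 24000 nM in this assay, at which 2 of the 2 values shown sit). The step that the two limits leave unreadable from compound 1 to compound 2 cannot be read in size; both of its ends sit at the limit (the limit of < 24000 nM in this assay, at which 2 of the 2 values shown sit). Compound 3 `COc1cc(/C=C/C(=O)OCc2nc(C)c(C)nc2C)cc(OC)c1OC` differs from compound 2 by methoxy in place of hydrogen on an aromatic carbon. Among the measured compounds shown here, the one measured step, a step that the two limits leave unreadable from compound 1 to compound 2, is the same kind of change but gives no size, so there is no basis for expecting a step in this assay in either direction beyond the scatter. Compound 3 is expected to give a step that the limit leaves unreadable from compound 2 to compound 3, and most likely it will again return only a limit. The estimate for compound 3 in this assay is 15000 nM, with a range from 3000 nM to 60000 nM.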

Compound 3, half-maximal effective concentration: < 24000 nM
Compound 3: no number, only a limit (the forecaster's own chance of this, stated with the estimate: 75%); the middle value is on the limit's open side.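

Compound 3, like compound 2, returns only a limit of the assay and not a number in this assay, so no step between them can be read: the limit of < 24000 nM in this assay, at which 3 of the 3 values shown sit.

The compounds shown leave open whether methoxy in place of hydrogen on an aromatic carbon changes this read-out at all, and by how much.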